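This account rests on a few compounds, and the source may have more. Where it says the series, first, only, none or still open, it means among the compounds named here.

Working notes on the series. In a functional assay on MIA PaCa-2 cells (Homo sapiens) for antiproliferative activity, read by MTT assay, with a stated time of 72 h (a higher number here means a weaker inhibitor, a lower number a stronger inhibitor), compound 1 (`O=C1O/C(=C\Cn2cnc3cc[nH]c3c2=O)C(OCc2ccccc2)=C1OCc1ccccc1`) gives > 100000 nM, which is a limit of the assay and not a number. Compound 1 therefore has no measured potency to serve as a starting point. Two relatives do give numbers: compound 2 (`O=C1NC(O)(CCn2cnc3ccnc(Cl)c32)C(OCc2ccccc2)=C1OCc1ccccc1`) reads 60000 nM and compound 3 (`COc1nc(OC)c2c(ccn2C/C=C2\OC(=O)C(OCc3ccccc3)=C2OCc2ccccc2)n1`) reads 33900 nM, and these two values lie within the usual scatter of each other.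

Compound 4 (`O=C1O/C(=C\Cn2cnc3c(Cl)c(F)nc(F)c32)C(OCc2ccccc2)=C1OCc1ccccc1`) has not yet been measured. It differs from compound 1 on a saturated chain carbon bound to a double-bonded chain carbon: a group of 12 heavy atoms (6 carbon, 3 nitrogen, 2 fluorine, 1 chlorine; one five-membered aromatic ring with 2 hetero atoms, one six-membered aromatic ring with 1 hetero atom) in place of a group of 10 heavy atoms (6 carbon, 3 nitrogen, 1 oxygen; one five-membered aromatic ring with 1 hetero atom, one six-membered aromatic ring with 2 hetero atoms), on a saturated chain carbon bound to a double-bonded chain carbon. The entering group carries fluorine and chlorine, which the leaving group lacks.

Within the data shown here, no pair of measured compounds differs in one place, so the series offers no direct measure of a single change in this assay. A move toward a stronger inhibitor is expected, though only a modest one, since compound 3 at 33900 nM shows the level that measurable members have reached so far. The estimated change is an at least 5.0-fold lower number from compound 1 to compound 4 (0.69 log units; beyond the scatter), and its size remains uncertain because the starting value is only a limit.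

Compound 4 is expected at 20000 nM, with an estimated range of 4000 nM to 80000 nM.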

Compound 4, half-maximal inhibitory concentration: > 100000 nM
Compound 4 gave a limit, no number (the forecaster's own chance of this, stated with the estimate: 20%); middle value at least 5.0-fold (0.69 log units) from the limit.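

Compound 1 and compound 4 both end at a limit of the assay and not a number, so no step between them can be read, for this reason: the limit of > 100000 nM in this assay, at which 2 of the 4 values shown sit.

The compounds shown leave open whether the group entering in compound 4 changes antiproliferative potency at all, and how far past that limit either compound lies.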